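This account rests on a few compounds, and the source may have more. Where it says the series, first, only, none or still open, it means among the compounds named here.

In a toxicity assay on HUVEC cells (Homo sapiens) for inhibition (on this read-out lower numbers stand for stronger inhibition of growth and higher numbers for weaker inhibition of growth), three compounds have been measured. Compound 1 `COc1cc(OC)cc(N2CCN(C(=O)c3oc(C)nc3-c3ccccc3F)CC2)c1` gives 0.118 ug/mL and compound 3 `COc1cc(OC)cc(N2CCN(C(=O)c3oc(C)nc3-c3cccc(F)c3)CC2)c1` gives 0.126 ug/mL, while compound 2 `Cc1cc(C)cc(N2CCN(C(=O)c3oc(C)nc3-c3ccccc3)CC2)c1`, at 0.356 ug/mL, has the highest number of the three, beyond the scatter from both others. Compound 4 `Cc1nc(-c2ccccc2)c(C(=O)N2CCN(c3cccc(C#N)c3)CC2)o1` differs from compound 2 by 3-cyanophenyl in place of 3,5-dimethylphenyl on an amine nitrogen in a ring. For the measured compounds named here, the only measured single change, a 1.1-fold higher number from compound 1 to compound 3 (0.03 log units; within the scatter), lies within the scatter and concerns a different place, so no measured step speaks directly to this exchange. No step beyond the scatter is therefore expected in this assay. The estimated step is a 1.2-fold lower number from compound 2 to compound 4 (0.07 log units; within the scatter). Compound 4 is expected at 0.3 ug/mL, with an estimated range of 0.1 ug/mL to 0.9 ug/mL.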

Compound 4, concentration for 50% growth inhibition: 2.52 ug/mL
Compound 4: the middle estimate sits 8.4-fold (0.92 log units) below what was measured; the whole stated range lies below it.
By their numbers in this assay, from the lowest: compounds 1 and 3 (each within the scatter of the next); then compound 2; then compound 4.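

In this assay, the group on the amine nitrogen in a ring turns out to matter: 3-cyanophenyl in place of 3,5-dimethylphenyl weakens growth inhibition (a 7.1-fold higher number from compound 2 to compound 4 (0.85 log units; beyond the scatter)). The only earlier step (a 1.1-fold higher number from compound 1 to compound 3 (0.03 log units; within the scatter)) lay within the scatter and concerned a different place, so this is the first sign among these compounds that the result responds to a change at this position. Nothing available bears on why this exchange has this effect.

The compounds shown do not separate the arrival of the nitrile from the loss of the two methyl groups. As far as these compounds go, how a plain phenyl or a 3-methylphenyl would read at this position remains open.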